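A few compounds are considered here, and "the series" means these few. Any claim that something is new, unique, unknown or untested is made for them only; others in the source may bear on it.

Measured compounds:
compound 1, `COc1cc(C2CC(c3ccco3)=NN2C(C)=O)cc(OC)c1OC` — 10900 nM in a functional assay on OVCAR cells (Homo sapiens) for cytotoxicity, read by sulforhodamine B assay, with a stated time of 48 h; on this read-out lower numbers stand for stronger inhibition and higher numbers for weaker inhibition
compound 2, `O=CCN1N=C(c2ccc3ccccc3c2)CC1c1ccccc1` — 21500 nM in this assay

Compound 2 and compound 1 lie within the scatter of each other in this assay; no difference between them can be read. Compound 3, `COc1ccc(C2CC(c3ccc4ccccc4c3)=NN2CC=O)cc1`, is not yet measured. Compound 3 differs from compound 2 by methoxy in place of hydrogen on an aromatic carbon. Among the compounds with values here, no measured pair shows the effect of this change, so no step beyond the scatter is expected; the estimate for compound 3 stays near the number of compound 2, 21500 nM. Compound 3 is expected to give 18000 nM, between 7000 nM and 45000 nM. The expected step of a 1.2-fold lower number from compound 2 to compound 3 (0.08 log units; within the scatter) is within the scatter.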

Compound 3, half-maximal inhibitory concentration: 5790 nM
The estimate for compound 3 lay 3.1-fold (0.49 log units) above the measured number; measured number outside the range, below it.
By their numbers in this assay, from the lowest: compounds 3, 1 and 2 (each within the scatter of the next, the first and the last beyond it).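

Phenyl to 4-methoxyphenyl gives the first readable step in the series: in this assay, a 3.7-fold lower number from compound 2 to compound 3 (0.57 log units; beyond the scatter). The position para to a large group is therefore not silent in this assay, and methoxy there goes with stronger inhibition, on this single pair only. Nothing measured here gives a reason for the step.

Open, as far as these compounds go, is whether a hydroxyl, an amine or a carboxylic acid at this place moves the number the same way. Also open, from the compounds shown here alone, is whether a longer chain, such as ethoxy, goes further than methoxy.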